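Working notes: a chloro added to the aryl group

The source may report more compounds than this note shows. Statements on the series, on what has been measured and on what is new or still open speak of the compounds shown alone.

Measured so far:
compound 1 `Nc1scc(CN2CCN(CCCc3ccc(Cl)cc3)CC2)c1C(=O)c1ccc(Cl)cc1` gives 0%
compound 2 `Nc1scc(CN2CCN(c3cccc(Cl)c3)CC2)c1C(=O)c1ccc(Cl)cc1` gives 0%

In an assay on CHO cells for displacement of a labelled ligand from adenosine receptor A1 (Homo sapiens), read by scintillation counting, with a stated time of 120 min, tested at 10 uM (a higher number here means more inhibition at the concentration tested (going by the name of the read-out), a lower number less inhibition), compound 1 gives 0% and compound 2 gives 0%. The only step measured, no change at the digits printed from compound 1 to compound 2 (within the scatter), swapped the whole group on the ring amine nitrogen and moved nothing at the digits shown. Compound 2 therefore stands level with compound 1; the two values do not separate, and neither compound shows measurable displacement at the test concentration.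

Compound 3 `Nc1scc(CN2CCN(c3ccc(Cl)c(Cl)c3)CC2)c1C(=O)c1ccc(Cl)cc1` is the next member. It differs from compound 2 by chloro in place of hydrogen on an aromatic carbon.

Going by the values given here, only the step from compound 1 to compound 2 bears on this, and it was within the scatter even though it changed far more than a single substituent. The expected step of a number 2 percentage points higher from compound 2 to compound 3 (within the scatter) for compound 3 is therefore none beyond the scatter. Compound 3 is estimated at 2%, with a range of -8% to 15%.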

Compound 3, a percentage reported as inhibition, at one concentration (the size of the read-out at that concentration, not a potency): 1%
For compound 3 the middle estimate is 1 percentage points above the measured one; measured number inside the range.
By their numbers in this assay, from the lowest: compounds 1, 2 and 3 (each within the scatter of the next).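

In this assay, chloro in place of hydrogen on an aromatic carbon, ortho to a chloro group and para to a large group, gives a number 1 percentage points higher from compound 2 to compound 3 (within the scatter) and so does not separate the 3,4-dichlorophenyl compound from the 3-chlorophenyl one. The comparison with the longer substituent reads the same way: a number 1 percentage points higher from compound 1 to compound 3 (within the scatter) for 3,4-dichlorophenyl in place of 3-(4-chlorophenyl)propyl on the ring amine nitrogen, so this position adds a small single-atom change to the larger swap, and neither separates. Nothing available bears on why these values stay together.

As far as these compounds go, how a hydroxyl or an amine on this aromatic carbon would read stays open. Also open, from the compounds shown here alone, is whether any group on the ring amine nitrogen, such as a benzyl or a longer chain, gives a value that separates from these three.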